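Capping the sulfanyl group of compound 2 with methyl

The source may hold more compounds than are shown below. What is called first, only, known or untested is meant among the compounds shown, and "the series" means these compounds.

Measured in a functional assay on L1210 cells (Mus musculus) for inhibition; on this read-out higher numbers stand for weaker inhibition and lower numbers for stronger inhibition:
- compound 1 `C=C1[C@@H](O)[C@H](n2cnc3c(O)nc(N)nc32)O[C@@H]1CO`: > 200000 nM (a limit of the assay, not a number)
- compound 2 `C=C1[C@@H](O)[C@H](n2cnc3c(S)nc(N)nc32)O[C@@H]1CO`: 207000 nM

For the measured compounds named here, compound 2, at 207000 nM, holds the only true number in this assay so far, so it cannot yet be ranked against any other measured value. The next compound, compound 3 `C=C1[C@@H](O)[C@H](n2cnc3c(SC)nc(N)nc32)O[C@@H]1CO`, puts methyl in place of hydrogen on a sulfur, turning sulfanyl into methylsulfanyl (methyl in place of hydrogen on a sulfur).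

Going by the values given here, the one measured step that bears on this is a step that the limit leaves unreadable from compound 1 to compound 2. It introduced the sulfanyl group that now changes, but it offers no size to carry over because of the limit of > 200000 nM in this assay, at which 1 of the 2 values shown sits. Among the compounds with values here, with no sized step to guide the forecast, neither direction can be favoured, and the forecast starts from the value of compound 2 at 207000 nM. No change beyond the usual scatter is expected. The expected change is a 1.2-fold lower number from compound 2 to compound 3 (0.06 log units; within the scatter). For compound 3 the estimated value is 180000 nM, with an expected range from 60000 nM to 500000 nM. The result for compound 3 may also arrive only as a limit.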

Compound 3, half-maximal inhibitory concentration: > 500000 nM
Compound 3 was reported as a limit; the forecaster's own chance of this, stated with the estimate: 35%; middle value at least 2.7-fold (0.44 log units) from the limit.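

In this assay, capping the sulfanyl group with methyl gives an at least 2.4-fold higher number from compound 2 to compound 3 (0.38 log units; beyond the scatter). For the compounds shown here, this is the first readable step at this position, and it shows that replacing the hydrogen on the sulfur with a single carbon weakens inhibition by more than the usual scatter of the assay. Compound 3 is reported as > 500000 nM, which is a limit of the assay and not a number, so the true size of the loss could be larger than the printed step, and the two steps that start from compound 1 cannot be read.

Going by these compounds alone, compound 2 therefore remains the only compound here with a true number, and how far compound 3 lies past its limit stays unknown. Going by these compounds, it also stays open whether the loss belongs to methyl alone or extends to a longer chain on the sulfur such as ethyl or benzyl, and how an amine in place of the sulfanyl group on the same aromatic carbon would read out.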